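This account rests on a few compounds, and the source may have more. Where it says the series, first, only, none or still open, it means among the compounds named here.

Measured so far:
compound 1, `CCN1CCN(C(=S)SCC(=O)N(Cc2ccc(OC)cc2)c2cc(OC)c(OC)c(OC)c2)CC1`: 3070 nM
compound 2, `COc1ccc(CN(C(=O)CSC(=S)N2CCCc3cc(C)ccc32)c2cc(OC)c(OC)c(OC)c2)cc1`: 5210 nM

Among the compounds with values here, in a functional assay on KYSE-450 cells (Homo sapiens) for inhibition, read by CCK-8 assay, with a stated time of 48 h (a lower number here means a stronger inhibitor, a higher number a weaker inhibitor), compound 1 carries the lower of the two numbers, but its only neighbour is close, a 1.7-fold higher number from compound 1 to compound 2 (0.23 log units; within the scatter), so no real order between the two is claimed. Compound 3, `COc1ccc(CN(C(=O)CSC(=S)N2CCc3ccccc3C2)c2cc(OC)c(OC)c(OC)c2)cc1`, is not yet measured. It differs from compound 1 in one place: 1,2,3,4-tetrahydroisoquinolin-2-yl in place of 4-ethylpiperazin-1-yl on a thiocarbonyl carbon. Within the data shown here, the one measured step that bears on this is the exchange at the same thiocarbonyl carbon, which gave a 1.7-fold higher number from compound 1 to compound 2 (0.23 log units; within the scatter); there the entering group was 6-methyl-1,2,3,4-tetrahydroquinolin-1-yl, a close relative of the group entering here, and the number hardly moved. For compound 3 a shift of similar size is expected, a 1.5-fold higher number from compound 1 to compound 3 (0.17 log units; within the scatter), within the scatter and if anything toward a higher number. The estimate for compound 3 is therefore 4500 nM, with a range of 2000 nM to 10000 nM.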

Compound 3, half-maximal inhibitory concentration: > 20000 nM
Compound 3 was reported as a limit (the forecaster's own chance of this, stated with the estimate: 5%); middle value at least 4.4-fold (0.64 log units) from the limit.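

In this assay the group on the thiocarbonyl carbon can clearly change the reading: 1,2,3,4-tetrahydroisoquinolin-2-yl in place of 4-ethylpiperazin-1-yl gives an at least 6.5-fold higher number from compound 1 to compound 3 (0.81 log units; beyond the scatter) in this series. Related groups are also not interchangeable at this position, since 1,2,3,4-tetrahydroisoquinolin-2-yl in place of 6-methyl-1,2,3,4-tetrahydroquinolin-1-yl gives an at least 3.8-fold higher number from compound 2 to compound 3 (0.58 log units; beyond the scatter) here, whereas compound 1 and compound 2 could not be separated. Both steps give only a lower bound on the change, the reading for compound 3 being a limit and not a number: the limit of > 20000 nM in this assay, at which 1 of the 3 values shown sits.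

Three compounds do not settle which feature of 1,2,3,4-tetrahydroisoquinolin-2-yl sets it apart from the other two groups. Also open, as far as these compounds go, is how a morpholin-4-yl or a dimethylamino group on the same thiocarbonyl carbon would read.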